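The compounds below may be only part of what the source reports. "The series", "measured", "known", "first", "only" and "open" are said of these compounds alone.

Measured compounds in a functional assay on the whole organism (strain Sprague-Dawley) for inhibition, with Rattus norvegicus as the target, read by paw edema, with stated times of 1 h and 2 h, at a dose of 70 mg/kg by the subcutaneous route; on this read-out higher numbers stand for more inhibition at the one dose given (going by the name of the read-out) and lower numbers for less inhibition:
compound 1 `Cc1c(-n2c(-c3ccccc3)c(-c3ccccc3)c3c(Nc4ccccc4)ncnc32)n(C)n(-c2ccccc2)c1=O` gives 5.11%
compound 2 `Cc1c(-n2c(N)c(C(N)=O)c(-c3ccccc3)c2-c2ccccc2)n(C)n(-c2ccccc2)c1=O` gives 26.2%

Of the two compounds measured, compound 1 stands lowest, and compound 2 lies above it by a gap that is beyond the usual scatter. Compound 2 shares only part of the core of compound 1, so nothing can be said of what separates the two structures beyond what their two values show.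

Compound 3 `Cc1c(-n2c(-c3ccccc3)c(-c3ccccc3)c3c(N/N=C/c4ccccc4)ncnc32)n(C)n(-c2ccccc2)c1=O` is the compound not yet measured. It differs from compound 1 in one place: a group of 8 heavy atoms (7 carbon, 1 nitrogen; one six-membered aromatic ring of carbon only) in place of a group of 6 heavy atoms (6 carbon; one six-membered aromatic ring of carbon only), on a nitrogen on an aromatic ring. Among the measured compounds shown here, no pair of measured compounds that differ in one place is at hand, so there is no step from which to judge this change. Compound 1 gives 5.11%, which leaves little room for a downward move; the expected step for compound 3 is a number 6.9 percentage points higher from compound 1 to compound 3 (within the scatter), a small upward move that may not exceed the scatter. Compound 3 is thus expected to give about 12%, with a plausible range from 0% to 30%.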

Compound 3, a percentage reported as inhibition, in the whole organism at one dose (the size of the read-out at that dose, not a potency): 59.6%
Estimate against measurement, compound 3: 47.6 percentage points below; the whole stated range lies below it.
By their numbers in this assay, from the lowest: compound 1; then compound 2; then compound 3.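

In this assay, the group on a nitrogen on an aromatic ring proves to be a sensitive place in the core of compound 1: putting the group of 8 heavy atoms in place of phenyl gives a number 54.5 percentage points higher from compound 1 to compound 3 (beyond the scatter). Both groups carry one six-membered aromatic ring of carbon only, so this large change comes with the ring kept and the link to it altered, with one more nitrogen and one double bond outside aromatic rings. No measurement at hand explains the size of this step.

The compounds shown leave open whether the added nitrogen, the double bond or the longer link accounts for the step. They also leave open how the value would respond to a saturated chain, a carboxylic acid or a pyridine ring at this place.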